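Amide aryl variation on the shared flavonol-amide core

A few compounds are considered here, and "the series" means these few. Any claim that something is new, unique, unknown or untested is made for them only; others in the source may bear on it.

Compound 2 `Cc1cc(C)cc(C(=O)Nc2cccc(-c3oc4cc(-c5ccc(F)cc5)ccc4c(=O)c3O)c2)c1` in a functional assay on HeLa cells (Homo sapiens) for antiproliferative activity, read by CCK-8 assay, with a stated time of 72 h (a higher number here means a weaker inhibitor, a lower number a stronger inhibitor), gives 5540 nM; compound 1 `O=C(Nc1cccc(-c2oc3cc(-c4ccc(F)cc4)ccc3c(=O)c2O)c1)c1ccccc1F` in this assay gives 5630 nM, and the step of a 1.0-fold lower number from compound 1 to compound 2 (0.01 log units; within the scatter) leaves the two level, so compound 2 stands alongside compound 1 rather than apart from it. Compound 3 `CCCc1ccc(C(=O)Nc2cccc(-c3oc4cc(-c5ccc(F)cc5)ccc4c(=O)c3O)c2)cc1` carries 4-propylphenyl in place of 3,5-dimethylphenyl on a carbonyl carbon. For the measured compounds named here, only the step from compound 1 to compound 2 bears on this change, and it produced no movement beyond the scatter. For compound 3 the step of a 1.0-fold lower number from compound 2 to compound 3 (0.00 log units; within the scatter) is therefore expected to be small, with no direction claimed. Compound 3 is estimated at 5500 nM, within a range from 2500 nM to 12000 nM.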

Compound 3, half-maximal inhibitory concentration: 8790 nM
The estimate for compound 3 lay 1.6-fold (0.20 log units) below the measured number; the measured number falls inside the stated range.
By their numbers in this assay, from the lowest: compounds 2, 1 and 3 (each within the scatter of the next).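

The step to 4-propylphenyl from 3,5-dimethylphenyl, a 1.6-fold higher number from compound 2 to compound 3 (0.20 log units; within the scatter), and the step to it from 2-fluorophenyl, a 1.6-fold higher number from compound 1 to compound 3 (0.19 log units; within the scatter), both lie within the scatter of this assay. On this carbonyl carbon, a third aryl group with a different substitution pattern therefore gives a number that cannot be told apart from the other two, so the level result is no longer confined to a single pair. No data at hand bear on the reason for this result.

On these data alone, whether an amine, a carboxylic acid or a longer chain on this aryl ring would shift the number beyond the scatter remains open. So does whether changes elsewhere on the shared core would do so.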